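Anilino variation on the shared quinazoline-sulfonamide series

This account rests on a few compounds, and the source may have more. Where it says the series, first, only, none or still open, it means among the compounds named here.

Measured in a functional assay on NCI-H1975 cells (Homo sapiens) for antiproliferative activity, read by MTT assay, with a stated time of 72 h; a higher number here means a weaker inhibitor, a lower number a stronger inhibitor:
compound 1 `COc1cc2ncnc(Nc3ccc(Br)cc3)c2cc1OCCCCC(=O)Nc1ccc(S(N)(=O)=O)cc1`: 23300 nM
compound 2 `COc1ccc(Nc2ncnc3cc(OC)c(OCCCCC(=O)Nc4ccc(S(N)(=O)=O)cc4)cc23)cc1OC`: 9230 nM

Compound 2 gives the lowest of the two numbers in this assay; compound 1 sits a 2.5-fold lower number from compound 1 to compound 2 (0.40 log units; beyond the scatter) away. Compound 3 `CCc1ccc(Nc2ncnc3cc(OC)c(OCCCCC(=O)Nc4ccc(S(N)(=O)=O)cc4)cc23)cc1` differs from compound 2 in one place: 4-ethylphenyl in place of 3,4-dimethoxyphenyl on a nitrogen on an aromatic ring. Within the data shown here, the one measured step, a 2.5-fold lower number from compound 1 to compound 2 (0.40 log units; beyond the scatter), shows that putting 3,4-dimethoxyphenyl on that nitrogen in place of a plain 4-substituted phenyl moved the number down modestly. Removing it again for 4-ethylphenyl is expected to move the number back up by a similar modest amount, a 1.7-fold higher number from compound 2 to compound 3 (0.24 log units; within the scatter), in this assay. Compound 3 is therefore estimated at 16000 nM, within 6000 nM to 40000 nM.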

Compound 3, half-maximal inhibitory concentration: 10300 nM
Beside the measured number, compound 3's estimate is 1.6-fold (0.19 log units) above it, and the stated range covers the measured number.
By their numbers in this assay, from the lowest: compounds 2 and 3 (each within the scatter of the next); then compound 1.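

In this assay 4-ethylphenyl and 3,4-dimethoxyphenyl on the nitrogen cannot be told apart, with a 1.1-fold higher number from compound 2 to compound 3 (0.05 log units; within the scatter) as the step, so the earlier gain is not specific to 3,4-dimethoxyphenyl. Ethyl in place of bromo on the aromatic carbon gives a 2.3-fold lower number from compound 1 to compound 3 (0.35 log units; beyond the scatter) and is of similar size to the earlier step, so 4-bromophenyl is the one that stands apart among these three compounds. No measured evidence bears on why these numbers differ or match.

From the compounds shown here alone, an amine, a carboxylic acid or a longer chain in place of ethyl remains open, as does whether any group on this nitrogen brings the number well below those of compound 2 and compound 3.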